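Methyl on the Fused Core: An Estimate for Compound 4

This account rests on a few compounds, and the source may have more. Where it says the series, first, only, none or still open, it means among the compounds named here.

Measured so far in a functional assay on cells (Cancer cell lines, Homo sapiens) for inhibition; on this read-out lower numbers stand for stronger inhibition of growth and higher numbers for weaker inhibition of growth:
compound 1 `Cc1cc(-c2nc3sc(C)cn3c2/C=N/NC(=N)N)c(C)s1` gives 33100 nM;
compound 2 `N=C(N)N/N=C/c1c(-c2cccs2)nc2sccn12` gives 26900 nM;
compound 3 `Cc1cc(-c2nc3sccn3c2/C=N/NC(=N)N)c(C)s1` gives 33900 nM.

Compound 4 `Cc1cn2c(/C=N/NC(=N)N)c(-c3cccs3)nc2s1` is not yet measured. It stands to compound 2 as compound 1 stands to compound 3. That earlier change, (methyl in place of hydrogen on an aromatic carbon), produced a 1.0-fold lower number from compound 3 to compound 1 (0.01 log units; within the scatter). The change to compound 4, (methyl in place of hydrogen on an aromatic carbon), is the same change, its place described in the same words. The two cores differ otherwise: thiophen-2-yl in place of 2,5-dimethylthiophen-3-yl on an aromatic carbon, a change that produced a 1.3-fold higher number from compound 2 to compound 3 (0.10 log units; within the scatter). All three measured numbers sit within the scatter of one another, so no order among them can be stated. The methyl is expected to behave on the core of compound 2 as the step of a 1.0-fold lower number from compound 3 to compound 1 (0.01 log units; within the scatter) shows it did on the core of compound 3. Compound 4 is therefore expected to show a 1.0-fold lower number from compound 2 to compound 4 (0.01 log units; within the scatter). For compound 4 the estimate is 26500 nM, expected between 14000 nM and 50000 nM.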

Compound 4, concentration for total growth inhibition: 17400 nM
Compound 4: the middle estimate sits 1.5-fold (0.18 log units) above what was measured; low and high end bracket the measured number.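

In this assay, methyl in place of hydrogen on an aromatic carbon gives a 1.5-fold lower number from compound 2 to compound 4 (0.19 log units; within the scatter), and this agrees with the same change on the other core: the same change on two cores in this assay, a 1.0-fold lower number (0.01 log units; within the scatter) from compound 3 to compound 1 and a 1.5-fold lower number (0.19 log units; within the scatter) from compound 2 to compound 4, 1.5-fold (0.18 log units) apart, within the scatter of two such steps

The exchange of the thiophene groups gives a 1.9-fold lower number from compound 1 to compound 4 (0.28 log units; within the scatter), and it too agrees across the two cores: the same change on two cores in this assay, a 1.3-fold higher number (0.10 log units; within the scatter) from compound 2 to compound 3 and a 1.9-fold higher number (0.28 log units; within the scatter) from compound 4 to compound 1, 1.5-fold (0.18 log units) apart, within the scatter of two such steps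

Going by these compounds alone, all of these steps lie within the scatter, so the agreement shows only that neither change produced a readable effect on either core, not that a real effect of the methyl carries from one core to another.

The compounds shown leave open whether an ethyl chain, an amine or a carboxylic acid in place of the methyl would give a step beyond the scatter. They also leave open how a phenyl ring in place of the thiophene groups would read.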